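From a Hydroxylated Side Chain to a Plain Methyl

This account rests on a few compounds, and the source may have more. Where it says the series, first, only, none or still open, it means among the compounds named here.

Compound 1 `O=C(O)[C@@H]1CCCN1C(=O)CN(c1nc(Cl)nc2[nH]cnc12)C1CC1`: 7.29%
Compound 2 `O=C(CN(c1nc(Cl)nc2[nH]cnc12)C1CC1)N[C@@H](CC(=O)OCc1ccccc1)C(=O)OCc1ccccc1`: 6.68%
Compound 3 `C[C@@H](O)[C@H](NC(=O)CN(c1nc(Cl)nc2[nH]cnc12)C1CC1)C(=O)O`: 24%

Of the compounds shown here, three built on one shared core have been measured in a functional assay on the whole organism (Tail, strain ICR) with Mus musculus as the target, in the tail flick test, with a stated time of 150 min, at a dose of 25 umol/kg by the oral route; on this read-out higher numbers stand for a stronger effect at the one dose given and lower numbers for a weaker effect. Among them compound 3 stands highest; its nearest neighbour is compound 1, which sits beyond the scatter below it, and compound 2 lies furthest away, also beyond the scatter. Within the data shown here, the only single-point step among the measured compounds is a number 16.7 percentage points higher from compound 1 to compound 3 (beyond the scatter), a modest gain that came with (1-carboxy-2-hydroxypropyl)amino in place of 2-carboxypyrrolidin-1-yl on a carbonyl carbon.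

Compound 4 `C[C@H](NC(=O)CN(c1nc(Cl)nc2[nH]cnc12)C1CC1)C(=O)O` differs from compound 3 in one place: methyl in place of 1-hydroxyethyl on a saturated chain carbon bound to an amide-type nitrogen and a carbonyl carbon. Among the measured compounds shown here, no measured pair changes this position, so the data give no direct guide to the size or direction of the step. For the measured compounds named here, the one step available, a number 16.7 percentage points higher from compound 1 to compound 3 (beyond the scatter), brought the 1-hydroxyethyl-bearing group in with a modest rise, which makes some loss on removing it a reasonable guess, though the step is of a different kind and the guess is loose. Compound 4 is therefore expected to sit somewhat below compound 3, a step of a number 9 percentage points lower from compound 3 to compound 4 (within the scatter) that may well fall within the scatter. The estimate for compound 4 in this assay is 15%, with a range from 3% to 30%.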

Compound 4, a percentage reported as activity, at one dose (the size of the read-out at that dose, not a potency): 14.7%
The estimate for compound 4 lay 0.3 percentage points above the measured number; measured number inside the range.
By their numbers in this assay, from the lowest: compounds 2, 1, 4 and 3 (each within the scatter of the next, the first and the last beyond it).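

In this assay, replacing 1-hydroxyethyl with methyl on this saturated chain carbon gives a number 9.3 percentage points lower from compound 3 to compound 4 (within the scatter), so the hydroxyl-bearing side chain is not shown to be required for the effect at this single dose. The comparison with the 2-carboxypyrrolidin-1-yl compound also becomes less clear-cut: (1-carboxy-2-hydroxypropyl)amino gave a number 16.7 percentage points higher from compound 1 to compound 3 (beyond the scatter), whereas (1-carboxyethyl)amino gives a number 7.4 percentage points higher from compound 1 to compound 4 (within the scatter), which leaves compound 4 within the scatter of both compound 1 and compound 3. No supporting measurement explains why these groups give these numbers.

Going by these compounds, it remains open whether a longer chain, such as propyl or butyl, or a chain ending in an amine would move the read-out beyond the scatter at this position. On these data alone, the role of the hydroxyl also remains open, since a hydroxymethyl group, or 1-hydroxyethyl with its stereocentre inverted, would separate the effect of that oxygen from the effect of the chain length that changes with it.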